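Swapping the Aryl Group on the Sulfonyl Sulfur

A few compounds are considered here, and "the series" means these few. Any claim that something is new, unique, unknown or untested is made for them only; others in the source may bear on it.

Of the compounds shown here, three built on a shared core have been tested in a functional assay on A549 cells (Homo sapiens) for antiproliferative activity, read by MTT assay, with a stated time of 72 h; on this read-out higher numbers stand for weaker inhibition and lower numbers for stronger inhibition. Compound 1 `CN(C(=O)CCc1ccccc1)c1ccc2[nH]c(-c3n[nH]c4ccccc34)cc2n1` gives 18100 nM. Compound 2 `CN(C(=O)c1ccco1)c1ccc2[nH]c(-c3n[nH]c4ccccc34)cc2n1`, with furan-2-yl in place of phenethyl on the carbonyl carbon, gives 15500 nM, and the step of a 1.2-fold lower number from compound 1 to compound 2 (0.07 log units; within the scatter). Compound 3 `Cc1ccc(S(=O)(=O)N(C)c2ccc3[nH]c(-c4n[nH]c5ccccc45)cc3n2)cc1` carries a (4-methylphenyl)sulfonyl on the nitrogen on the aromatic ring and gives 27100 nM, the highest of the three numbers, although its steps from the other two, a 1.5-fold higher number from compound 1 to compound 3 (0.18 log units; within the scatter) and a 1.7-fold higher number from compound 2 to compound 3 (0.24 log units; within the scatter), are both within the scatter.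

Compound 4 `COc1ccc(OC)c(S(=O)(=O)N(C)c2ccc3[nH]c(-c4n[nH]c5ccccc45)cc3n2)c1` has not yet been measured. It differs from compound 3 in one place: 2,5-dimethoxyphenyl in place of 4-methylphenyl on a sulfonyl sulfur. For the measured compounds named here, no measured step changes the aryl group on the sulfonyl sulfur, so none bears directly on this exchange. The nearest guides are the replacements of the whole group on the nitrogen on the aromatic ring, a 1.5-fold higher number from compound 1 to compound 3 (0.18 log units; within the scatter) and a 1.7-fold higher number from compound 2 to compound 3 (0.24 log units; within the scatter), which stayed within the scatter even though an entire acyl group was exchanged for a sulfonyl. A change confined to the aryl ring of that sulfonyl is therefore expected to shift this assay no further than the scatter, in no set direction, so that a 1.0-fold lower number from compound 3 to compound 4 (0.00 log units; within the scatter). On that basis compound 4 is expected to give 27000 nM, with a range from 12000 nM to 60000 nM.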

Compound 4, half-maximal inhibitory concentration: 19400 nM
The estimate for compound 4 lay 1.4-fold (0.14 log units) above the measured number; low and high end bracket the measured number.
By their numbers in this assay, from the lowest: compounds 2, 1, 4 and 3 (each within the scatter of the next).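

For the compounds shown here, the aryl group on the sulfonyl sulfur had not been varied in the earlier compounds, and in this assay the exchange of 4-methylphenyl for 2,5-dimethoxyphenyl gives a 1.4-fold lower number from compound 3 to compound 4 (0.15 log units; within the scatter), a step that stays within the scatter. At this place, on a sulfonyl sulfur whose other neighbour is the sulfonamide nitrogen, a group of 10 heavy atoms with 2 hydrogen-bond acceptors has thus taken the place of one of 7 heavy atoms with 0 hydrogen-bond acceptors, with no change in the number that can be told from scatter. No measurement of any property of these compounds is available to account for this step.

Going by these compounds alone, with only one exchange on the sulfonyl sulfur, it remains open whether the two methoxy groups would give the same result singly, or whether an aryl ring bearing a carboxylic acid or an amine would move the number beyond the scatter. It is equally open what would follow if a pyridine ring or a plain methyl stood on the sulfonyl sulfur in place of the aryl ring, or whether any such change would bring the number away from the level of these compounds.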